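This account rests on a few compounds, and the source may have more. Where it says the series, first, only, none or still open, it means among the compounds named here.

Of the compounds shown here, three built on one shared core have been tested in a functional assay on CCRF-CEM cells (Homo sapiens); on this read-out higher numbers stand for weaker inhibition and lower numbers for stronger inhibition. Compound 1 `O=C(/C=C/c1ccc(Br)cc1)Oc1ccc(/C=C2\CCCCC2=O)cc1` gives 131000 nM, and compound 3 `COc1ccc(C(=O)Oc2ccc(/C=C3\CCCCC3=O)cc2)cc1` gives 36100 nM. Compound 2 `CN(C)CC1CCC/C(=C\c2ccc(OC(=O)/C=C/c3ccc(Br)cc3)cc2)C1=O` gives 4440 nM, the lowest number of the three; compound 3 lies nearest to it and compound 1 furthest away, both gaps being beyond the scatter. Going by the values given here, the only pair that differs in one place is compound 1 and compound 2, and that step, a 30-fold lower number from compound 1 to compound 2 (1.47 log units; beyond the scatter), comes from (dimethylamino)methyl replacing hydrogen on a saturated ring carbon.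

Compound 4 `CN(C)CC1CCC/C(=C\c2ccc(OC(=O)c3ccc(Cl)cc3)cc2)C1=O` keeps that (dimethylamino)methyl group and differs from compound 2 in one place: 4-chlorophenyl in place of 2-(4-bromophenyl)ethenyl on a carbonyl carbon. Among the compounds with values here, no measured step covers this exchange directly. Compound 1 and compound 3 differ in the group on the carbonyl carbon as well, but in more than one way at once. Within the data shown here, their two values show only that compound 1 gives 131000 nM while compound 3 gives 36100 nM, a lower number. On that weak basis compound 4 is expected to give about 2500 nM, in a range from 800 nM to 8000 nM. This estimate means an expected step of a 1.8-fold lower number from compound 2 to compound 4 (0.25 log units; within the scatter), small enough that it may fall within the scatter.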

Compound 4, half-maximal inhibitory concentration: 6150 nM
For compound 4 the middle estimate is 2.5-fold (0.39 log units) below the measured one; the measured number falls inside the stated range.
By their numbers in this assay, from the lowest: compounds 2 and 4 (each within the scatter of the next); then compound 3; then compound 1.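

On a carbonyl carbon, with the (dimethylamino)methyl group kept in place, exchanging 2-(4-bromophenyl)ethenyl for 4-chlorophenyl gives a 1.4-fold higher number from compound 2 to compound 4 (0.14 log units; within the scatter) in this assay, so this position accepts both groups without a change beyond the scatter, even though the entering group has fewer heavy atoms and lacks the double bond outside the aromatic ring. This stands in contrast with the only other single-place step, a 30-fold lower number from compound 1 to compound 2 (1.47 log units; beyond the scatter), which is large and lies at a saturated ring carbon, so among the compounds shown only that exchange moves the number beyond the scatter. The exchange on the carbonyl carbon alters the halogen and the link to the ring at once, so the two alterations cannot be told apart here, and no measurement of any kind is at hand to explain the result.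

The compounds shown leave open whether the (dimethylamino)methyl group would have a similarly large effect alongside 4-chlorophenyl as it does alongside 2-(4-bromophenyl)ethenyl. They also leave open what a quite different group on the carbonyl carbon would do, such as a plain methyl, a longer saturated chain, or a phenyl ring carrying a carboxylic acid or an amine.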